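The source may report more compounds than this note shows. Statements on the series, on what has been measured and on what is new or still open speak of the compounds shown alone.

Within the data shown here, in a functional assay on KG-1 cells (Homo sapiens) for cytotoxicity, read by luminescence and CellTiter-Glo, with a stated time of 3 days (a lower number here means a stronger inhibitor, a higher number a weaker inhibitor), compound 1 `N#Cc1ccc(NC(=O)c2cc(-c3ccncc3)ccc2O)cc1` gives 7990 nM and stands highest of the two numbers so far, while compound 2 `N#Cc1ccc(NC(=O)c2ccc(Br)cc2O)c(Cl)c1` gives 790 nM and lies beyond the scatter below it. Among the measured compounds shown here, these two differ in more than one place, so no measured step isolates a single change. Compound 3 `N#Cc1ccc(NC(=O)c2cc(F)ccc2O)cc1` carries fluoro in place of pyridin-4-yl on an aromatic carbon, with fluoro in place of pyridin-4-yl on an aromatic carbon as the count of that change. In this assay a modest fall is expected, an estimated 2.0-fold lower number from compound 1 to compound 3 (0.30 log units; within the scatter) and no more. For the measured compounds named here, compound 2 at 790 nM is the only guide toward a lower number, and a weak one. For compound 3 the expected value is 4000 nM within an estimated range of 1200 nM to 14000 nM in this measurement.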

Compound 3, half-maximal inhibitory concentration: 2670 nM
Compound 3: the middle estimate sits 1.5-fold (0.18 log units) above what was measured; the range from low to high includes it.
By their numbers in this assay, from the lowest: compound 2; then compound 3; then compound 1.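

In this assay, fluoro in place of pyridin-4-yl on the aromatic carbon para to the hydroxy group gives a 3.0-fold lower number from compound 1 to compound 3 (0.48 log units; beyond the scatter) and so shows that this position does not need the aromatic ring to keep its activity. A single fluorine atom there does better than the larger group. No measurement shown gives a reason for this step.
The compounds shown leave open whether an amine or a methoxy group at this position would lower the number further. Compound 2 differs from the others in more than one place, so its steps cannot be read.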